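A few compounds are considered here, and "the series" means these few. Any claim that something is new, unique, unknown or untested is made for them only; others in the source may bear on it.

Working notes on the series built on the shared core of compound 1 `C=C1CCC[C@]2(C)CCC(c3cn(-c4ccc(OC)cc4)nn3)=CC[C@@]12C`. In a functional assay on MCF7 cells (Homo sapiens) for cytotoxicity, read by MTT assay, with a stated time of 48 h (a higher number here means a weaker inhibitor, a lower number a stronger inhibitor), compound 1 gives 118000 nM, and compound 2 `C=C1CCC[C@]2(C)CCC(c3cn(-c4ccc(C(C)=O)cc4)nn3)=CC[C@@]12C` gives 65400 nM. These two values lie within the scatter of each other, so compound 2 stands level with compound 1 and neither ranks ahead.

Compound 3 `C=C1CCC[C@]2(C)CCC(c3cn(-c4cccc([N+](=O)[O-])c4)nn3)=CC[C@@]12C` has not yet been measured. It has 3-nitrophenyl in place of 4-acetylphenyl on an aromatic nitrogen of the five-membered aromatic ring with 3 nitrogen: 3-nitrophenyl in place of 4-acetylphenyl on an aromatic nitrogen. Among the measured compounds shown here, neither measured compound carries 3-nitrophenyl, so no measured step tests this group directly.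

For the measured compounds named here, the only measured step that bears on the change is a 1.8-fold lower number from compound 1 to compound 2 (0.26 log units; within the scatter). It swaps acetyl for methoxy on the same aromatic ring and stays within the scatter. With that single small step as the guide, the expected move is a 1.1-fold higher number from compound 2 to compound 3 (0.03 log units; within the scatter), which is expected to stay within the scatter in this assay, with no direction favoured. For compound 3 the estimated value is 70000 nM, with an expected range from 30000 nM to 150000 nM.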

Compound 3, half-maximal inhibitory concentration: 40300 nM
Compound 3: the middle estimate sits 1.7-fold (0.24 log units) above what was measured; low and high end bracket the measured number.
By their numbers in this assay, from the lowest: compounds 3, 2 and 1 (each within the scatter of the next, the first and the last beyond it).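

In this assay, 3-nitrophenyl in place of 4-acetylphenyl on the aromatic nitrogen gives a 1.6-fold lower number from compound 2 to compound 3 (0.21 log units; within the scatter) and so leaves compound 3 level with compound 2. Set against 4-methoxyphenyl at the same position, the same group gives a 2.9-fold lower number from compound 1 to compound 3 (0.47 log units; beyond the scatter) as the first modest separation in the series, so this position can register a change in the aryl group, while compound 2 remains within the scatter of both neighbours. No evidence at hand accounts for this separation.

The step from 4-methoxyphenyl to 3-nitrophenyl alters both the group and where it sits on the phenyl ring, and the compounds shown cannot separate those two contributions. Also open, from the compounds shown here alone, is how this assay would read an amine or a carboxylic acid on that phenyl ring, or a longer chain on the aromatic nitrogen in place of the ring.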